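Allylsulfanyl variant of the lowest-number ester

The compounds below may be only part of what the source reports. "The series", "measured", "known", "first", "only" and "open" are said of these compounds alone.

In an ADME assay on WI-38 cells (Homo sapiens) for antiproliferative activity, read by sulforhodamine B assay, with a stated time of 72 h (a lower number here means a stronger inhibitor, a higher number a weaker inhibitor), compound 2 `CCCSc1ccc2c3c(cccc13)C1=NC(=O)C(C(=O)OCC)=C12` gives 9600 nM, the lowest of the three numbers measured. Compound 1 `CCCSC(=O)COC(=O)C1=C2C(=NC1=O)c1cccc3cccc2c13` gives 25200 nM, and compound 3 `O=C(COC(=O)C1=C2C(=NC1=O)c1cccc3cccc2c13)OCC(F)(F)C(F)(F)F` gives 48300 nM; both stand beyond the scatter from compound 2. Among the measured compounds shown here, the only measured single-point step, a 1.9-fold higher number from compound 1 to compound 3 (0.28 log units; within the scatter), sits on a carbonyl carbon and does not touch the sulfur-bearing chain. Compound 4 `C=CCSc1ccc2c3c(cccc13)C1=NC(=O)C(C(=O)OCC)=C12` differs from compound 2 by vinyl in place of ethyl on a saturated chain carbon bound to a sulfur, propylsulfanyl becoming allylsulfanyl. For the measured compounds named here, no measured step bears on this exchange, so no shift beyond the scatter is expected, and compound 2 serves as the anchor. Compound 4 is estimated at 9500 nM, with a range of 4000 nM to 22000 nM. The expected step of a 1.0-fold lower number from compound 2 to compound 4 (0.00 log units; within the scatter) is essentially none.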

Compound 4, half-maximal inhibitory concentration: 4600 nM
Estimate against measurement, compound 4: 2.1-fold (0.31 log units) above; measured number inside the range.
By their numbers in this assay, from the lowest: compound 4; then compound 2; then compounds 1 and 3 (each within the scatter of the next).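

In this assay, the sulfur-bearing chain is sensitive to a small change: allylsulfanyl in place of propylsulfanyl gives a 2.1-fold lower number from compound 2 to compound 4 (0.32 log units; beyond the scatter). The heavy-atom count stays the same, and the counted difference is one double bond outside aromatic rings, so a change of this size at this position is enough to move the number beyond the scatter. No supporting data on the origin of this shift are available. Open, on these data alone, is whether a longer chain such as butylsulfanyl, or an amine in place of the sulfur-linked chain, would follow compound 4 or compound 2.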